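Swapping a benzylamine for a chlorophenyl: cytotoxicity outlook

The source may report more compounds than this note shows. Statements on the series, on what has been measured and on what is new or still open speak of the compounds shown alone.

Compound 1 `Cc1ccccc1CNc1nn(-c2ccc(F)cc2F)cc1CNCCN1CCN(C)CC1` was examined in an ADME assay on Huh-7 cells (Homo sapiens) for cytotoxicity; a lower number here means that less compound is tolerated, a higher number that more compound is tolerated. In this assay compound 1 gives > 20000 nM, which is a limit of the assay rather than a number. Compound 2 `Cc1ccccc1-c1nn(-c2cc(F)ccc2F)cc1CNCCN1CCN(C)CC1` shows the same kind of result: in this assay compound 2 gives > 20000 nM, again only a limit. Compound 1 thus sits at the limit of > 20000 nM in this assay, at which 2 of the 2 values shown sit, alongside every value shown.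

Compound 3 `CN1CCN(CCNCc2cn(-c3ccc(F)cc3F)nc2-c2ccccc2Cl)CC1` has not been measured yet. It differs from compound 1 in one place: 2-chlorophenyl in place of (2-methylbenzyl)amino on an aromatic carbon. The (2-methylbenzyl)amino group departs and 2-chlorophenyl takes its place on an aromatic carbon of the shared core.

Among the compounds with values here, no step between measured compounds is available, so the outlook rests on the limits alone. Because compound 1 sits at the limit of > 20000 nM in this assay, at which 2 of the 2 values shown sit, compound 3 is expected to stay tolerated at the top of the tested range. The expected step is a step that the limit leaves unreadable from compound 1 to compound 3, none beyond the scatter. Compound 3 is estimated at 30000 nM, with a range from 15000 nM to 80000 nM.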

Compound 3, half-maximal cytotoxic concentration: > 20000 nM
Compound 3: no number, only a limit; the forecaster's own chance of this, stated with the estimate: 80%; the middle value is on the limit's open side.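

Within the data shown here, compound 1 and compound 3 each give only a limit of the assay in this assay, not a number, so no step between them can be read. What stays open is whether 2-chlorophenyl in place of (2-methylbenzyl)amino changes how much compound the cells tolerate, as every result stops at the same point: the limit of > 20000 nM in this assay, at which 3 of the 3 values shown sit.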